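Moving the methylpyrazole attachment point in compound 2

A few compounds are considered here, and "the series" means these few. Any claim that something is new, unique, unknown or untested is made for them only; others in the source may bear on it.

Compound 2 `Cn1nccc1-c1ccccc1NCC1=NCCN1` was examined in an in vitro functional assay on cells (Fibroblast) for agonist activity at Alpha-1D adrenergic receptor (Homo sapiens); on this read-out higher numbers stand for an effect only at larger amounts of compound and lower numbers for an effect already at smaller amounts. In this assay compound 2 gives only a limit, < 100000 nM. Compound 1 `Cc1n[nH]c(-c2ccccc2NCC2=NCCN2)n1` likewise gives only a limit, < 5020 nM. Compound 3 `CCn1nccc1-c1ccccc1NCC1=NCCN1` also stands at a limit, < 100000 nM. The step from compound 1 to compound 2, a step that the two limits leave unreadable from compound 1 to compound 2, and the step from compound 2 to compound 3, a step that the two limits leave unreadable from compound 2 to compound 3, thus have no readable size, as the limit of < 100000 nM in this assay, at which 2 of the 3 values shown sit, and the limit of < 5020 nM in this assay, at which 1 of the 3 values shown sits, show. Compound 4 `Cn1cc(-c2ccccc2NCC2=NCCN2)cn1` differs from compound 2 by 1-methyl-1H-pyrazol-4-yl in place of 1-methyl-1H-pyrazol-5-yl on an aromatic carbon. Neither measured step bears readably on this change, so no direction can be expected beyond the scatter. Compound 4 is estimated at 30000 nM, between 3000 nM and 150000 nM. The expected step is a step that the limit leaves unreadable from compound 2 to compound 4.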

Compound 4, half-maximal effective concentration: < 100000 nM
Compound 4 gave a limit, no number; the forecaster's own chance of this, stated with the estimate: 60%; the middle value lies beyond the limit too.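

In this assay compound 4 gives only a limit, < 100000 nM. Going by these compounds alone, no step to compound 4 from compound 1 or compound 2 can be read. As far as these compounds go, whether 1-methyl-1H-pyrazol-4-yl and 1-methyl-1H-pyrazol-5-yl differ at all in this assay stays open.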